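From nitro to methoxy on the shared core

The source may hold more compounds than are shown below. What is called first, only, known or untested is meant among the compounds shown, and "the series" means these compounds.

Values in a functional assay on MCF7 cells (Homo sapiens) for cytotoxicity, read by MTT assay, with a stated time of 48 h; on this read-out higher numbers stand for weaker inhibition and lower numbers for stronger inhibition:
- Compound 1 `O=C(CSc1nnc(-c2ccncc2)o1)N/N=C/c1ccc(Cl)cc1`: 15300 nM
- Compound 2 `O=C(CSc1nnc(-c2ccncc2)o1)N/N=C/c1ccc(Br)cc1`: 19100 nM
- Compound 3 `O=C(CSc1nnc(-c2ccncc2)o1)N/N=C/c1ccc([N+](=O)[O-])cc1`: 31800 nM

Two measured steps place compound 3 among its neighbours: a 2.1-fold higher number from compound 1 to compound 3 (0.32 log units; beyond the scatter), and a 1.7-fold higher number from compound 2 to compound 3 (0.22 log units; within the scatter). Compound 4 `COc1ccc(/C=N/NC(=O)CSc2nnc(-c3ccncc3)o2)cc1` keeps the shared core but has methoxy in place of nitro on an aromatic carbon. For the measured compounds named here, no measured compound carries methoxy, so the only guide is how little this assay has moved with changes at this spot. Those steps are the two above and a 1.2-fold higher number from compound 1 to compound 2 (0.10 log units; within the scatter). A shift beyond the scatter is therefore not expected, though a slightly lower number is possible. The expected change is a 1.4-fold lower number from compound 3 to compound 4 (0.16 log units; within the scatter). For compound 4 the estimated value is 22000 nM, with an expected range of 9000 nM to 50000 nM.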

Compound 4, half-maximal inhibitory concentration: 17600 nM
The estimate for compound 4 lay 1.3-fold (0.10 log units) above the measured number; measured number inside the range.
By their numbers in this assay, from the lowest: compounds 1, 4, 2 and 3 (each within the scatter of the next, the first and the last beyond it).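

In this assay methoxy cannot be told apart from the halogens at this position: a 1.2-fold higher number from compound 1 to compound 4 (0.06 log units; within the scatter) and a 1.1-fold lower number from compound 2 to compound 4 (0.04 log units; within the scatter) are both within the scatter. Swapping nitro for methoxy gives a 1.8-fold lower number from compound 3 to compound 4 (0.26 log units; within the scatter) and also stays within the scatter, so among these four groups only compounds 1 and 3 stand apart. No evidence is available to explain these numbers.

Going by these compounds, it remains open whether an amine, a carboxylic acid or a longer chain at this spot would move the number further. Changes elsewhere on the shared core also remain open.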